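Series notes: aryl variation at the ethyl-linked phenyl ring

The source may report more compounds than this note shows. Statements on the series, on what has been measured and on what is new or still open speak of the compounds shown alone.

Of the compounds shown here, three of the shared core have been measured in a functional assay on HEK293 cells for agonist activity at Bombesin receptor subtype-3 (Homo sapiens), read by luminescence and calcium flux, with a stated time of 10 min; on this read-out higher numbers stand for an effect only at larger amounts of compound and lower numbers for an effect already at smaller amounts. Compound 1 `CCC(C)(C)Cc1c[nH]c(CCc2ccc(-n3ncnn3)cc2)n1` gives 422 nM, compound 2 `CCC(C)(C)Cc1c[nH]c(CCc2ccc(-n3ccnn3)cc2)n1` gives 641 nM, and compound 3 `CCC(C)(C)Cc1c[nH]c(CCc2ccc(-c3ccc(F)cn3)cc2)n1` gives 66 nM. The step of a 1.5-fold higher number from compound 1 to compound 2 (0.18 log units; within the scatter) stays within the scatter, whereas a 6.4-fold lower number from compound 1 to compound 3 (0.81 log units; beyond the scatter) and a 9.7-fold lower number from compound 2 to compound 3 (0.99 log units; beyond the scatter) both lie beyond it, so compound 3 holds the lowest number of the three and is the only one set apart from the rest.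

Compound 4 `CCC(C)(C)Cc1c[nH]c(CCc2ccc(-c3cccnc3)cc2)n1` carries pyridin-3-yl in place of 5-fluoropyridin-2-yl on an aromatic carbon. Within the data shown here, no measured pair shows this exact exchange; the closest information is that both steps into compound 3, a 6.4-fold lower number from compound 1 to compound 3 (0.81 log units; beyond the scatter) and a 9.7-fold lower number from compound 2 to compound 3 (0.99 log units; beyond the scatter), ended at a six-membered ring with one hetero atom, which compound 4 keeps, while the fluorine is lost and the nitrogen sits elsewhere in the ring. A modest rise in the number is therefore expected, a 2.3-fold higher number from compound 3 to compound 4 (0.36 log units; beyond the scatter), without reaching the level of compound 1. The estimate for compound 4 in this assay is 150 nM, with a range from 50 nM to 500 nM.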

Compound 4, half-maximal effective concentration: 131 nM
Compound 4: middle estimate off by 1.1-fold (0.06 log units), on the high side, within the range that was stated.
By their numbers in this assay, from the lowest: compounds 3 and 4 (each within the scatter of the next); then compounds 1 and 2 (each within the scatter of the next).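

The exchange of 5-fluoropyridin-2-yl for pyridin-3-yl on this aromatic carbon, para to a large group, gives a 2.0-fold higher number from compound 3 to compound 4 (0.30 log units; within the scatter), so the two groups cannot be told apart on this read-out. The separation from the five-membered groups now holds for a second six-membered aromatic ring with 1 hetero atom, seen in a 4.9-fold lower number from compound 2 to compound 4 (0.69 log units; beyond the scatter) and in a 3.2-fold lower number from compound 1 to compound 4 (0.51 log units; beyond the scatter), and so does not rest on the fluorine-bearing group of compound 3 alone. Nothing available explains these differences in terms of a measured property.

The exchange alters the fluorine and the pyridine attachment together, so the share of each stays unresolved. Also open, on these data alone, is how a plain phenyl, a pyridin-2-yl without fluorine, or a ring bearing an amine or a carboxylic acid would fare at this place.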